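A few compounds are considered here, and "the series" means these few. Any claim that something is new, unique, unknown or untested is made for them only; others in the source may bear on it.

Within the data shown here, compound 1 `O=c1[nH]c(=O)n([C@@H]2O[C@H](CO)[C@@H](O)[C@H]2O)cc1C#CC1CCCCC1` is one of three compounds measured in an ADME assay on A549 cells (Homo sapiens) for cytotoxicity, read by MTT assay; a lower number here means that less compound is tolerated, a higher number that more compound is tolerated. In this assay compound 1 gives 127000 nM, the lowest of the three numbers, yet its gaps to compound 2 `O=c1[nH]cc(C#CC2CCCCC2)c(=O)[nH]1`, which gives 245000 nM, and to compound 3 `CCC#Cc1c[nH]c(=O)[nH]c1=O`, which gives 253000 nM, both lie within the scatter, so the three stand together rather than apart. None of these compounds differs from another in a single place, so no measured step guides the next move. Compound 4 `O=c1[nH]c(=O)n([C@@H]2O[C@H](CO)[C@@H](O)[C@H]2O)cc1C#CC(O)c1ccccc1` departs from compound 1 by one change: hydroxy(phenyl)methyl in place of cyclohexyl on a triple-bonded carbon. With hydroxy(phenyl)methyl in place of cyclohexyl on a triple-bonded carbon and the rest of compound 1 kept, the step in this assay is expected to be small, most likely none beyond the scatter, with only a slight lean toward a lower number. Compound 4 is therefore estimated at 100000 nM in this assay, within a range from 40000 nM to 250000 nM. The step that this estimate means is a 1.3-fold lower number from compound 1 to compound 4 (0.10 log units; within the scatter), expected to stay inside the scatter.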

Compound 4, half-maximal cytotoxic concentration: 34200 nM
Beside the measured number, compound 4's estimate is 2.9-fold (0.47 log units) above it; the measured number lies below the stated range.
By their numbers in this assay, from the lowest: compound 4; then compounds 1, 2 and 3 (each within the scatter of the next).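

In this assay the group on the triple-bonded carbon proves able to move the number: hydroxy(phenyl)methyl in place of cyclohexyl gives a 3.7-fold lower number from compound 1 to compound 4 (0.57 log units; beyond the scatter) and so stands beyond the scatter. The earlier compounds shown here could not show this, as none differed from another in one place and their numbers stood together. The change replaces a non-aromatic carbon ring with an aromatic one and brings in a hydrogen-bond donor and acceptor, but no measurement on hand bears on why the number falls.

The compounds shown leave open whether the step follows the phenyl ring or the hydroxyl, a question that a plain benzyl group on the same triple-bonded carbon would help to separate. Also open, on these data alone, is whether the same change gives a like step on the core of compound 2.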